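Oxygen-for-sulfur swap in the five-membered ring of compound 1

The source may hold more compounds than are shown below. What is called first, only, known or untested is meant among the compounds shown, and "the series" means these compounds.

Measured compounds:
- compound 1 `O=S(=O)(CC1=NCCO1)c1n[nH]cc1-c1ccccc1`: 57.5%
- compound 2 `O=S(=O)(CC1=NCCS1)c1c(-c2ccc(Cl)cc2)nn(-c2ccccc2)c1-c1ccc(Cl)cc1`: "not active" (no number reported)
- compound 3 `O=S(=O)(CC1=NCCS1)C1=NNCC1c1ccc(Cl)cc1`: "not active" (no number reported)

In a functional assay, read by Griess assay, with a stated time of 150 min, tested at 100 ug/mL (on this read-out lower numbers stand for a weaker effect and higher numbers for a stronger effect at the one concentration tested), compound 1 gives 57.5%. In this assay compound 2 gives "not active" (no number reported). In this assay compound 3 gives "not active" (no number reported). Going by the values given here, compound 1 thus stands as the only entry with a number; the other two entries carry no number at all. Among the compounds with values here, no two measured compounds differ in one place only, so no step between measured values can be computed, and compounds 2 and 3 differ from compound 1 in several places at once.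

Compound 4 `O=S(=O)(CC1=NCCS1)c1n[nH]cc1-c1ccccc1` is the next entry. Relative to compound 1 the change is a group of 5 heavy atoms (3 carbon, 1 nitrogen, 1 sulfur; one five-membered non-aromatic ring with 2 hetero atoms) in place of a group of 5 heavy atoms (3 carbon, 1 nitrogen, 1 oxygen; one five-membered non-aromatic ring with 2 hetero atoms), on a saturated chain carbon bound to a sulfonyl sulfur. The step in this assay is expected to be small, if any, and not clearly beyond the scatter, with a slight lean downward; the estimate for compound 4 is 47% (range 15% to 75%). The expected step from the measured value is a number 10.5 percentage points lower from compound 1 to compound 4 (beyond the scatter).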

Compound 4, a percentage reported as activity, at one concentration (the size of the read-out at that concentration, not a potency): "not active" (no number reported)
For compound 4 the study gives words and no number, and the estimate cannot be compared.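

No new step can be read: compound 4 carries words and no number, so it cannot be set against compound 1. The compounds shown leave open how large any effect of the sulfur-containing ring is in this series. No supporting measurement bears on this result.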